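Phenyl for phenoxyethyl: expecting the next cytotoxicity value

A few compounds are considered here, and "the series" means these few. Any claim that something is new, unique, unknown or untested is made for them only; others in the source may bear on it.

compound 1 `CCSC(=S)OCC(=O)c1ccc(OC)cc1` — 2990 nM
compound 2 `CCSC(=S)SCC(=O)c1ccc(C(=O)NCCOc2ccccc2)cc1` — 18200 nM

Of the compounds shown here, two have been tested in a functional assay on HeLa cells (Homo sapiens) for cytotoxicity, read by resazurin assay, with a stated time of 72 h; on this read-out higher numbers stand for weaker inhibition and lower numbers for stronger inhibition. Compound 1 `CCSC(=S)OCC(=O)c1ccc(OC)cc1` gives 2990 nM, while compound 2 `CCSC(=S)SCC(=O)c1ccc(C(=O)NCCOc2ccccc2)cc1` gives 18200 nM. Compound 2 therefore stands at the higher of the two numbers, the weaker inhibitor, with compound 1 lying beyond the usual scatter below it. Compound 3 `CCSC(=S)SCC(=O)c1ccc(C(=O)Nc2ccccc2)cc1` differs from compound 2 in one place: phenyl in place of 2-phenoxyethyl on an amide-type nitrogen. Among the measured compounds shown here, no step of this kind has been measured, so direction and size are uncertain; a small move toward a lower number, close to the scatter, is expected, a 1.5-fold lower number from compound 2 to compound 3 (0.18 log units; within the scatter). Compound 3 is expected to give 12000 nM, within 3000 nM to 40000 nM.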

Compound 3, half-maximal inhibitory concentration: 25800 nM
Compound 3: middle estimate off by 2.2-fold (0.33 log units), on the low side; the measured number falls inside the stated range.
By their numbers in this assay, from the lowest: compound 1; then compounds 2 and 3 (each within the scatter of the next).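

In this assay, putting phenyl in place of 2-phenoxyethyl on the amide-type nitrogen gives a 1.4-fold higher number from compound 2 to compound 3 (0.15 log units; within the scatter) and leaves the two compounds indistinguishable. At this position, then, the smaller group without the oxygen gives a reading that cannot be told apart from that of the larger group, though both rings are aromatic. Nothing available explains why this change has so little effect.

From the compounds shown here alone, whether a basic amine or a carboxylic acid on this nitrogen would shift the number remains open. So does the effect of a longer chain, such as 4-phenylbutyl.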